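Changing the Amine at the End of the Side Chain

The compounds below may be only part of what the source reports. "The series", "measured", "known", "first", "only" and "open" are said of these compounds alone.

Of the compounds shown here, three have been measured in a functional assay on HT-29 cells (Homo sapiens) for inhibition, read by MTT assay, with a stated time of 72 h; a lower number here means a stronger inhibitor, a higher number a weaker inhibitor. Compound 1 `COc1cc2c(Oc3ccc(NC(=O)c4nn(-c5ccccc5C(F)(F)F)c(=O)cc4C)cc3F)ccnc2cc1OCCCN1CCC(C)CC1` gives 180 nM, and compound 2 `COc1cc2c(Oc3ccc(NC(=O)c4nn(-c5ccccc5OC(F)(F)F)c(=O)cc4C)cc3F)ccnc2cc1OCCCN1CCC(C)CC1` gives 250 nM. Among the measured compounds shown here, the only change between them, trifluoromethoxy in place of trifluoromethyl on an aromatic carbon, reads a 1.4-fold higher number from compound 1 to compound 2 (0.14 log units; within the scatter), so the two numbers cannot be told apart. Compound 3 `COc1ccc(-n2nc(C(=O)Nc3ccc(Oc4ccnc5cc(OCCCN6CCCC6)c(OC)cc45)c(F)c3)c(C)cc2=O)cc1` gives 3300 nM, the highest of the three numbers; its gaps to compound 2 and to compound 1 both lie beyond the scatter, which makes compound 3 the weakest inhibitor of the three measured.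

Compound 4 `COc1ccc(-n2nc(C(=O)Nc3ccc(Oc4ccnc5cc(OCCCN6CCC(C)CC6)c(OC)cc45)c(F)c3)c(C)cc2=O)cc1` is compound 3 with one change: 4-methylpiperidin-1-yl in place of pyrrolidin-1-yl on a saturated chain carbon, three bonds along the chain from an oxygen on an aromatic ring. For the measured compounds named here, no measured step bears directly on this change. Compounds 1 and 2 carry the entering group, but they differ from compound 3 in more than one place, so their large gap to compound 3 cannot be assigned to the amine alone. Going by the values given here, the one measured step concerns a different part of the molecule and is within the scatter. With this little guidance, the step expected from compound 3 to compound 4 in this assay is a 2.2-fold lower number from compound 3 to compound 4 (0.34 log units; beyond the scatter), leaning toward a lower number but quite uncertain. Compound 4 is therefore estimated at 1500 nM, within a range from 400 nM to 6000 nM.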

Compound 4, half-maximal inhibitory concentration: 5450 nM
Compound 4: the middle estimate sits 3.6-fold (0.56 log units) below what was measured, and the stated range covers the measured number.
By their numbers in this assay, from the lowest: compounds 1 and 2 (each within the scatter of the next); then compounds 3 and 4 (each within the scatter of the next).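

In this assay, replacing pyrrolidin-1-yl with 4-methylpiperidin-1-yl at the end of the side chain reads a 1.7-fold higher number from compound 3 to compound 4 (0.22 log units; within the scatter), so with 4-methoxyphenyl on the aromatic nitrogen these two amines cannot be told apart at this position. Among the compounds shown here, compound 4 also shares its 4-methylpiperidin-1-yl amine with compounds 1 and 2, which isolates the group on the aromatic nitrogen for the first time: placing 4-methoxyphenyl there gives a 22-fold higher number from compound 2 to compound 4 (1.34 log units; beyond the scatter) and a 30-fold higher number from compound 1 to compound 4 (1.48 log units; beyond the scatter). The large gaps that could not be assigned earlier can now be tied to that group rather than to the amine, at least in this small set.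

From the compounds shown here alone, it remains open whether the amine swap would also leave the number unmoved with 2-(trifluoromethyl)phenyl on the aromatic nitrogen, and whether a morpholine, a dimethylamino group or a longer chain at the end of the side chain would shift it. No measured property of these compounds is at hand to explain why the group on the aromatic nitrogen produces such large steps.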